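Swapping the Indazole Ring in a Sulfonamide Modulator

This account rests on a few compounds, and the source may have more. Where it says the series, first, only, none or still open, it means among the compounds named here.

Measured compounds:
Compound 1 `CCN(Cc1ccccc1)C(=O)C1CCN(S(=O)(=O)c2ccncc2)CC1` gives "not determined" (no result reported) in a functional assay on CHO cells for positive allosteric modulation of muscarinic acetylcholine receptor M5 (Homo sapiens), read by calcium flux; a lower number here means a smaller maximal response, a higher number a larger maximal response.
Compound 2 `CCN(Cc1ccccc1)C(=O)C1CCN(S(=O)(=O)c2ccc3[nH]ncc3c2)CC1` gives 86%.

Both compounds share a common core bearing a sulfonyl group, and they differ only in the aromatic group attached to that sulfonyl sulfur. In this assay, among the measured compounds shown here, compound 2 provides the only number in hand, with compound 1 adding no figure to compare against, so no step between measured compounds can be drawn here. Compound 3 `CCN(Cc1ccccc1)C(=O)C1CCN(S(=O)(=O)c2ccc3nsnc3c2)CC1` takes the next step from compound 2: a group of 9 heavy atoms (6 carbon, 2 nitrogen, 1 sulfur; one five-membered aromatic ring with 3 hetero atoms, one six-membered aromatic ring of carbon only) in place of a group of 9 heavy atoms (7 carbon, 2 nitrogen; one five-membered aromatic ring with 2 hetero atoms, one six-membered aromatic ring of carbon only), on a sulfonyl sulfur. For the measured compounds named here, with a single measured value and no measured step for guidance, the expected change is modest, most likely within the usual scatter or a small drop. The estimate is that the step of a number 8 percentage points lower from compound 2 to compound 3 (within the scatter) stays near the present level, and compound 3 is expected to give 78%, within a range from 50% to 100%.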

Compound 3, largest response reached (reported as percent of maximum), in percent of the reference or control that the assay uses: 81%
Compound 3: the middle estimate sits 3 percentage points below what was measured; measured number inside the range.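

In this assay, the step to a group with a five-membered aromatic ring with 3 hetero atoms on the sulfonyl sulfur gives a number 5 percentage points lower from compound 2 to compound 3 (within the scatter) and so leaves the two maximal responses indistinguishable. This first readable step shows that this position tolerates this exchange, even though 1H-indazol-5-yl has 1 hydrogen-bond donor and the entering group has 0 hydrogen-bond donors. No measurement in hand explains why the two compounds match.

On these data alone, whether a fused two-ring group is needed here remains open, since compound 1 gives "not determined" (no result reported) and therefore offers no comparison. It is also unknown whether a plain phenyl group or a phenyl group carrying an amine on the sulfonyl sulfur would retain a similar maximal response.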